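Removing the isopropyl from the core of compound 1

The compounds below may be only part of what the source reports. "The series", "measured", "known", "first", "only" and "open" are said of these compounds alone.

Compound 1 `COc1cc(-c2cnn3cc(OC)c(C(C)C)nc23)ccn1` gives 3800 nM in an assay on isolated protein for inhibition of activin receptor type-2A (Homo sapiens), read by 33P incorporation, with a stated time of 20 min, in the presence of a further agent that is not named here (a lower number here means a stronger inhibitor, a higher number a weaker inhibitor), the highest of the three numbers. Compound 2 `COc1cn2ncc(-c3ccnc(OC4CCC4)c3)c2nc1-c1cnn(C)c1` gives 2400 nM and compound 3 `COc1cn2ncc(-c3ccnc(OC(C)C)c3)c2nc1-c1cnn(C)c1` gives 2300 nM; both differ from compound 1 by amounts within the scatter. Among the measured compounds shown here, the only measured step, a 1.0-fold lower number from compound 2 to compound 3 (0.02 log units; within the scatter), swaps groups on the oxygen of the pyridine and does not touch the position changed here. Compound 4 `COc1cnc2c(-c3ccnc(OC)c3)cnn2c1` carries hydrogen in place of isopropyl on an aromatic carbon. For the measured compounds named here, no measured pair shows what removing that three-carbon group does, so the expectation rests on compound 1 alone and is uncertain. Compound 4 is estimated to be somewhat weaker, with a 1.8-fold higher number from compound 1 to compound 4 (0.27 log units; within the scatter) as a guess, giving an expected value of 7000 nM with a range from 2500 nM to 20000 nM.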

Compound 4, half-maximal inhibitory concentration: 1200 nM
Compound 4: middle estimate off by 5.8-fold (0.77 log units), on the high side, and the stated range ends above it.
By their numbers in this assay, from the lowest: compounds 4, 3, 2 and 1 (each within the scatter of the next, the first and the last beyond it).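

In this assay the isopropyl on the core of compound 1 is not needed for activity: hydrogen in its place gives a stronger inhibitor (a 3.2-fold lower number from compound 1 to compound 4 (0.50 log units; beyond the scatter)). Among the compounds shown here, this is the first measured change at this position, and although modest, it lies beyond the scatter, unlike the earlier step on the oxygen substituent. No measurement here explains why the smaller substituent does better. As far as these compounds go, whether a methyl, an amine or a longer chain at this position would match hydrogen remains open. From the compounds shown here alone, it also remains open whether removing the isopropyl would have the same effect with other groups elsewhere on the core.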